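The source may hold more compounds than are shown below. What is called first, only, known or untested is meant among the compounds shown, and "the series" means these compounds.

Four closely related compounds are compared in a functional assay on HT-29 cells (Homo sapiens) for cytotoxicity, read by MTT assay, with a stated time of 72 h; on this read-out lower numbers stand for stronger inhibition of growth and higher numbers for weaker inhibition of growth. Compound 1 `CS/C(=N\C(=O)c1cc2ccccc2s1)NC(=O)c1cc2ccccc2s1` and compound 2 `O=C(/N=C(/NC(=O)c1ccco1)[Se]Cc1ccccc1)c1ccco1` give numbers: in this assay compound 1 gives 88200 nM, and compound 2 gives 89100 nM. Compound 3 `C[Se]/C(=N\C(=O)c1cnc2ccccc2c1)NC(=O)c1cnc2ccccc2c1` is recorded in this assay as > 100000 nM. That entry is a limit of the assay and not a number, which matters because of the limit of > 100000 nM in this assay, at which 1 of the 3 values shown sits. Compound 3 therefore stands at the weak end of what was seen, and how far it lies from compound 1 and compound 2 cannot be read from the data.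

Compound 4 `O=C(/N=C(/NC(=O)c1cnc2ccccc2c1)[Se]Cc1ccccc1)c1cnc2ccccc2c1` has not been measured in this assay. It differs from compound 3 by one change: phenyl in place of hydrogen on a saturated chain carbon bound to a selenium atom. Within the data shown here, no measured pair shows what this change does here; the nearest comparison is that compound 2, which carries a benzyl group on selenium, sits at a weak value much like compound 1. The step of an at least 1.0-fold lower number from compound 3 to compound 4 (0.02 log units; that floor lies within the scatter) is expected to be small, towards slightly stronger inhibition at most, and possibly none beyond the scatter. Compound 4 is estimated at 95000 nM, within the range 50000 nM to 200000 nM, with a real chance that only a limit is reported.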

Compound 4, concentration for total growth inhibition: > 100000 nM
Compound 4 ended at the assay's limit (the forecaster's own chance of this, stated with the estimate: 50%); middle value at least 1.0-fold (0.02 log units) away from the limit.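

Among these compounds, no step from compound 3 to compound 4 can be read, because both entries in this assay are limits and not numbers: the limit of > 100000 nM in this assay, at which 2 of the 4 values shown sit. The compounds shown leave open whether going from methyl to benzyl changes growth inhibition at all in this pair.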